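The source may hold more compounds than are shown below. What is called first, only, known or untested is meant among the compounds shown, and "the series" means these compounds.

Compound 1 `Nc1cccc(-c2cn(CC(=O)Nc3nc4ccccc4s3)nn2)c1` gives 1110 nM in a functional assay on BMDM cells (Mus musculus, strain C57BL/6) for inhibition, with a stated time of 2 days (on this read-out higher numbers stand for weaker inhibition and lower numbers for stronger inhibition), the highest of the two numbers seen so far. Within the data shown here, compound 2 `O=C(Cn1cc(-c2ccccc2Cl)nn1)Nc1nccs1` gives 60 nM in this assay; it differs from compound 1 in more than one place, so the pair shows only that its number is far lower. Compound 3 `O=C(Cn1cc(-c2ccccc2Cl)nn1)Nc1nc2ccccc2s1`, not yet measured, differs from compound 1 in one place: 2-chlorophenyl in place of 3-aminophenyl on an aromatic carbon. Compound 2 carries the same 2-chlorophenyl and gives the far lower 60 nM. On that basis a decrease beyond the scatter is expected, a 9.3-fold lower number from compound 1 to compound 3 (0.97 log units; beyond the scatter). Compound 3 is expected to give about 120 nM, within 30 nM to 500 nM.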

Compound 3, half-maximal inhibitory concentration: > 30000 nM
Compound 3: a limit, no number; the forecaster's own chance of this, stated with the estimate: 5%; at least 250-fold (2.39 log units) between middle value and limit.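

Compound 3 carries a limit of the assay, not a number: the limit of > 30000 nM in this assay, at which 1 of the 3 values shown sits. Putting 2-chlorophenyl in place of 3-aminophenyl on this aromatic carbon gives an at least 27-fold higher number from compound 1 to compound 3 (1.43 log units; beyond the scatter), so on this core the change costs inhibition heavily. Compound 2, with the same 2-chlorophenyl, gives 60 nM, so that group alone does not set the number, and its outcome depends on the rest of the molecule.

Open, from the compounds shown here alone, is whether the amine or the chlorine drives the step. A plain phenyl or a 2-aminophenyl on the core of compound 1 would separate the two.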